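Aryl-linked amine variation in a shared flavone-type series

The source may hold more compounds than are shown below. What is called first, only, known or untested is meant among the compounds shown, and "the series" means these compounds.

Among the compounds with values here, compound 1 `COc1cc(OC)c2c(=O)cc(-c3ccc(OCCCN)cc3)oc2c1` stands highest of the two numbers measured in a functional assay (Homo sapiens) for antiproliferative activity, read by resazurin assay, with a stated time of 48 h, tested at 10 uM (a lower number here means a weaker effect, a higher number a stronger effect of the compound at the concentration tested), where compound 1 gives 39%; compound 2 `COc1cc(OC)c2c(=O)cc(-c3ccc(OCC(O)CN4CCCC4)cc3)oc2c1` gives 37%, and the only measured step, a number 2 percentage points lower from compound 1 to compound 2 (within the scatter), lies within the scatter. Compound 3 `COc1cc(OC)c2c(=O)cc(-c3ccc(NCCN(C)C)cc3)oc2c1` differs from compound 1 by (2-(dimethylamino)ethyl)amino in place of 3-aminopropoxy on an aromatic carbon. No measured step touches the atom joining the chain to the ring, so the one step shown gives no direction. Compound 3 is therefore expected to stay within the scatter of compound 1, with an estimated step of a number 1 percentage points higher from compound 1 to compound 3 (within the scatter), landing at 40% within the range 25% to 55%.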

Compound 3, a percentage reported as inhibition, at one concentration (the size of the read-out at that concentration, not a potency): 60%
The estimate for compound 3 lay 20 percentage points below the measured number; the whole stated range lies below it.
By their numbers in this assay, from the lowest: compounds 2 and 1 (each within the scatter of the next); then compound 3.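

In this assay, within the data shown here, the swap on this aromatic carbon is the first change to move the read-out beyond the scatter: with the ether-linked chains replaced by (2-(dimethylamino)ethyl)amino, the result is a number 21 percentage points higher from compound 1 to compound 3 (beyond the scatter) and a number 23 percentage points higher from compound 2 to compound 3 (beyond the scatter). The change from 3-aminopropoxy alters the linking atom, the chain and the terminal amine at once, so the step cannot be assigned to any one of them. Nothing available accounts for the step.

Open, going by these compounds, is whether the linking nitrogen or the terminal dimethylamino group carries the step. A 2-(dimethylamino)ethoxy group or a (3-aminopropyl)amino group on the same carbon would separate the two.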